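Compound 3 to compound 4: changing the oxygen-bound aryl group

A few compounds are considered here, and "the series" means these few. Any claim that something is new, unique, unknown or untested is made for them only; others in the source may bear on it.

- compound 1 `O=C(O)CC/C=C\CC1COC(c2cccs2)OC1c1cccnc1` gives 1000 nM
- compound 2 `O=C(O)CC/C=C\CC1COC(c2ccc3ccccc3c2)OC1c1cccnc1` gives 1780 nM
- compound 3 `CSc1ccc(OC(C)(C)C2OCC(C/C=C\CCC(=O)O)C(c3cccnc3)O2)c([N+](=O)[O-])c1` gives 4.47 nM

In a functional assay for inhibition, with Homo sapiens as the target (on this read-out higher numbers stand for weaker binding and lower numbers for tighter binding), compound 3 has the lowest number of the three, well beyond the scatter from both others. Still unmeasured, compound 4 `COc1ccccc1OC(C)(C)C1OCC(C/C=C\CCC(=O)O)C(c2cccnc2)O1` differs from compound 3 by a group of 8 heavy atoms (7 carbon, 1 oxygen; one six-membered aromatic ring of carbon only) in place of a group of 11 heavy atoms (7 carbon, 1 nitrogen, 2 oxygen, 1 sulfur; one six-membered aromatic ring of carbon only), on an oxygen on a saturated carbon and so carries 2-methoxyphenyl on that oxygen. For the measured compounds named here, the only measured single-place step (a 1.8-fold higher number from compound 1 to compound 2 (0.25 log units; within the scatter)) lies within the scatter and concerns a different group, on a saturated ring carbon, so it offers little guidance. Going by the values given here, no measured step covers the group on the oxygen. A moderate move to a higher number is therefore expected in this assay (a 3.4-fold higher number from compound 3 to compound 4 (0.53 log units; beyond the scatter)). The estimate for compound 4 is 15 nM (expected range 3 nM to 80 nM).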

Compound 4, dissociation constant: 224 nM
Compound 4: the middle estimate sits 15-fold (1.17 log units) below what was measured; the whole stated range lies below it.
By their numbers in this assay, from the lowest: compound 3; then compound 4; then compounds 1 and 2 (each within the scatter of the next).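

In this assay the group on the oxygen on a saturated carbon proves a sensitive place: 2-methoxyphenyl in place of the group of 11 heavy atoms gives a 50-fold higher number from compound 3 to compound 4 (1.70 log units; beyond the scatter) and so makes a large step, unlike the earlier step at another place, which lay within the scatter. Both groups carry one six-membered aromatic ring of carbon only, so that ring alone does not secure the low number of compound 3. No available measurement explains this step.

Which part of the group of 11 heavy atoms matters remains open. Also open, from the compounds shown here alone, is how an unsubstituted phenyl or an amine-bearing group would read at this place.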